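A chalcone series and an expected pyridyl step

A few compounds are considered here, and "the series" means these few. Any claim that something is new, unique, unknown or untested is made for them only; others in the source may bear on it.

Measured compounds:
compound 1, `COc1ccc(/C=C/C(=O)c2ccccc2-c2cccc(F)c2)cc1`, 110 nM
compound 2, `COc1ccc(/C=C/C(=O)c2ccccc2-c2ccc(F)nc2)cc1`, 290 nM
compound 3, `COc1ccc(/C=C/C(=O)c2ccccc2-c2cccc(F)c2)cc1OC`, 150 nM

Of the compounds shown here, three have been tested in a functional assay on HepG2 cells (Homo sapiens) for antiproliferative activity, read by sulforhodamine B assay, with a stated time of 48 h; on this read-out lower numbers stand for stronger inhibition and higher numbers for weaker inhibition. Compound 1 gives 110 nM, and its two one-place relatives are both measured there too. Compound 2 differs from compound 1 in that (6-fluoropyridin-3-yl in place of 3-fluorophenyl on an aromatic carbon), a change that made a 2.6-fold higher number from compound 1 to compound 2 (0.42 log units; beyond the scatter). Compound 3 differs from compound 1 in that (methoxy in place of hydrogen on an aromatic carbon), a change that made only a 1.4-fold higher number from compound 1 to compound 3 (0.13 log units; within the scatter), so compound 1 and compound 3 cannot be told apart on this read-out.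

Compound 4, `COc1ccc(/C=C/C(=O)c2ccccc2-c2ccc(F)nc2)cc1OC`, has not yet been measured in this assay. It is built from compound 3 by the change in which (6-fluoropyridin-3-yl in place of 3-fluorophenyl on an aromatic carbon). This is the same change that carries compound 1 to compound 2, with the same surroundings at the place where it is made, and it occurs twice among the four compounds. Among the compounds with values here, the only measured example of it is the step from compound 1 to compound 2. On that one example it is expected that compound 4 will show a step of about a 2.6-fold higher number from compound 3 to compound 4 (0.41 log units; beyond the scatter) in this assay, because the same change gave a 2.6-fold higher number from compound 1 to compound 2 (0.42 log units; beyond the scatter). A single example leaves the size of the step uncertain, and the two cores, differing as told under compound 3, may not answer it alike. The estimate for compound 4 in this assay is 390 nM, with a likely range from 200 nM to 800 nM.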

Compound 4, half-maximal inhibitory concentration: 1000 nM
Compound 4: middle estimate off by 2.6-fold (0.41 log units), on the low side; the whole stated range lies below it.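

In this assay the exchange of 3-fluorophenyl for 6-fluoropyridin-3-yl gave a 6.7-fold higher number from compound 3 to compound 4 (0.82 log units; beyond the scatter), the same direction as on the core of compound 1, and the two steps cannot be told apart in size: the same change on two cores in this assay, a 2.6-fold higher number (0.42 log units; beyond the scatter) from compound 1 to compound 2 and a 6.7-fold higher number (0.82 log units; beyond the scatter) from compound 3 to compound 4, 2.5-fold (0.40 log units) apart, within the scatter of two such steps. The methoxy change, which could not be read between the first pair, gave a 3.4-fold higher number from compound 2 to compound 4 (0.54 log units; beyond the scatter) once the 6-fluoropyridin-3-yl group was in place, yet this pair of steps cannot be told apart either: the same change on two cores in this assay, a 1.4-fold higher number (0.13 log units; within the scatter) from compound 1 to compound 3 and a 3.4-fold higher number (0.54 log units; beyond the scatter) from compound 2 to compound 4, 2.5-fold (0.40 log units) apart, within the scatter of two such steps. This shows that the direction of the exchange carried from one core to the other in the one case available, but it does not show that the size of the step depends on the core, that it is fixed, or that the two changes reinforce each other, and two pairs are too few for a rule.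

On these data alone, whether a pyridine ring without fluorine, or one carrying a chlorine or an amine instead, would give a step in the same direction stays open, as does how a hydroxy or an ethoxy group would behave in place of the added methoxy. The compounds shown also leave open whether these steps would look the same in a cell line other than HepG2.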